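A few compounds are considered here, and "the series" means these few. Any claim that something is new, unique, unknown or untested is made for them only; others in the source may bear on it.

Measured so far:
- compound 1, `COC(=O)C1=C(C)N=C(C)/C(=C(/O)OC)C1c1cccc(OCc2c(C(N)=O)no[n+]2[O-])c1`, 1200 nM
- compound 2, `COC(=O)C1=C(C)N=C(C)/C(=C(/O)OC)C1c1cccc(OCc2no[n+]([O-])c2C(N)=O)c1`, 710 nM
- compound 3, `COC(=O)C1=C(C)N=C(C)/C(=C(/O)OC)C1c1ccccc1OCc1c(C(N)=O)no[n+]1[O-]`, 560 nM

These three compounds were tested in a functional assay (aorta) with Rattus norvegicus as the target, in the presence of a further agent that is not named here; a higher number here means that more compound is needed for the effect, a lower number that less compound is needed. Compound 1 and compound 2 share a core and differ only in how one ring group is joined: a group of 9 heavy atoms (3 carbon, 3 nitrogen, 3 oxygen; one five-membered aromatic ring with 3 hetero atoms) in place of a group of 9 heavy atoms (3 carbon, 3 nitrogen, 3 oxygen; one five-membered aromatic ring with 3 hetero atoms), on a saturated chain carbon bound to an oxygen on an aromatic ring. This gave a 1.7-fold lower number from compound 1 to compound 2 (0.23 log units; within the scatter), a step that stays within the usual scatter of the measurement. Compound 3 has a different core; the difference between the two cores is not broken down here. Compound 3 gives the lowest of the three numbers, but its gap to compound 2 is within the scatter, so no order between those two can be claimed.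

Compound 4, `COC(=O)C1=C(C)N=C(C)/C(=C(/O)OC)C1c1ccccc1OCc1no[n+]([O-])c1C(N)=O`, has not yet been measured. It is related to compound 3 by the same change that turns compound 1 into compound 2: a group of 9 heavy atoms (3 carbon, 3 nitrogen, 3 oxygen; one five-membered aromatic ring with 3 hetero atoms) in place of a group of 9 heavy atoms (3 carbon, 3 nitrogen, 3 oxygen; one five-membered aromatic ring with 3 hetero atoms), on a saturated chain carbon bound to an oxygen on an aromatic ring. Since that change gave a 1.7-fold lower number from compound 1 to compound 2 (0.23 log units; within the scatter), a similar small step is expected here, a 1.5-fold lower number from compound 3 to compound 4 (0.17 log units; within the scatter), with the reservation that a single earlier instance is a thin basis. Compound 4 is therefore estimated at 380 nM, most likely between 180 nM and 900 nM.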

Compound 4, half-maximal effective concentration: 550 nM
The estimate for compound 4 lay 1.4-fold (0.16 log units) below the measured number, and the stated range covers the measured number.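

In this assay, among these compounds, the swap of the ring group on compound 3 gives a 1.0-fold lower number from compound 3 to compound 4 (0.01 log units; within the scatter) and so leaves no step that can be told apart from the scatter. This suggests that, on these two cores, the swap shifts the number no more than repeated measurements would, and the cores give no sign of responding to it differently. It does not show that the swap is without effect in general, that it would stay this small on any further core, or why the numbers fall as they do, and the two steps compare as follows: the same change on two cores in this assay, a 1.7-fold lower number (0.23 log units; within the scatter) from compound 1 to compound 2 and a 1.0-fold lower number (0.01 log units; within the scatter) from compound 3 to compound 4, 1.7-fold (0.22 log units) apart, within the scatter of two such steps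

The compounds shown leave open whether the swap would stay this small if the amide on the five-membered ring were replaced by a nitrile or a carboxylic acid. They also leave open what a longer chain in place of the saturated chain carbon bound to the oxygen would do.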